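This account rests on a few compounds, and the source may have more. Where it says the series, first, only, none or still open, it means among the compounds named here.

In an assay on CHO cells for displacement of a labelled ligand from adenosine receptor A3 (Homo sapiens), read by scintillation counting, with a stated time of 60 min (on this read-out higher numbers stand for weaker inhibition and lower numbers for stronger inhibition), compound 1 `O=C(CCCc1ccccc1)Nc1nc2cc(Cl)ccc2c(=O)s1` gives 91.6 nM, while compound 2 `O=C(CCc1ccccc1)Nc1nc2ccccc2c(=O)s1` gives 390 nM, the higher of the two numbers, and its gap to compound 1 lies beyond the usual scatter of repeated measurements. Compound 3 `O=C(CCc1ccccc1F)Nc1nc2ccccc2c(=O)s1` differs from compound 2 by a single change: fluoro in place of hydrogen on an aromatic carbon. Among the measured compounds shown here, no measured pair shows this change, so nothing beyond the two values at hand can guide the expectation; the step from compound 2 to compound 3 is expected to be small, in either direction or none beyond the scatter. For compound 3 the expected value is 300 nM, within 120 nM to 800 nM, an expected step of a 1.3-fold lower number from compound 2 to compound 3 (0.11 log units; within the scatter).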

Compound 3, inhibition constant: >= 1000 nM
Compound 3: only a limit was reported; the forecaster's own chance of this, stated with the estimate: 3%; middle value at least 3.3-fold (0.52 log units) from the limit.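

Compound 3 gives only a limit of the assay, not a number: the limit of >= 1000 nM in this assay, at which 1 of the 3 values shown sits. In this assay, the change from phenyl to 2-fluorophenyl gives an at least 2.5-fold higher number from compound 2 to compound 3 (0.40 log units; beyond the scatter). This is the first step shown in one place, and it shows that a single fluoro on this ring, ortho to a large group, weakens inhibition by an amount the limit leaves unfixed. On these data alone, whether a methoxy group or a chloro at the same place would do the same stays open. So does whether the longer chain or the chloro on the core of compound 1 accounts for its stronger inhibition.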